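A few compounds are considered here, and "the series" means these few. Any claim that something is new, unique, unknown or untested is made for them only; others in the source may bear on it.

Of the compounds shown here, two have been measured: compound 1 `COc1cc(N(C)CCN(C)C)c(NC(=O)C(Cl)=C(Cl)Cl)cc1Nc1nccc(-c2cn(C)c3ccccc23)n1` and compound 2 `CCC/C=C\C(=O)Nc1cc(Nc2nccc(-c3cn(C)c4ccccc34)n2)c(OC)cc1N(C)CCN(C)C`.

In a functional assay on NCI-H1975 cells (Homo sapiens) for antiproliferative activity, read by MTT assay, with a stated time of 72 h (a lower number here means a stronger inhibitor, a higher number a weaker inhibitor), compound 1 reaches only the limit of > 50000 nM. In this assay, among the compounds with values here, compound 2 gives 1220 nM, the only number recorded. Within the data shown here, the one measured step, an at least 40-fold lower number from compound 1 to compound 2 (1.61 log units; beyond the scatter), concerns the acyl group and not the ring carbon now varied. Compound 3 `CCC/C=C\C(=O)Nc1cc(Nc2nc(C)cc(-c3cn(C)c4ccccc34)n2)c(OC)cc1N(C)CCN(C)C` differs from compound 2 by methyl in place of hydrogen on an aromatic carbon. Among the measured compounds shown here, no measured step bears on this change, so no shift beyond the scatter is expected, and the estimated step is a 1.2-fold higher number from compound 2 to compound 3 (0.09 log units; within the scatter). Compound 3 is expected to give about 1500 nM, between 400 nM and 6000 nM.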

Compound 3, half-maximal inhibitory concentration: 254 nM
Compound 3: middle estimate off by 5.9-fold (0.77 log units), on the high side; the whole stated range lies above it.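

Methyl in place of hydrogen on the aromatic carbon next to the ring nitrogen gives a 4.8-fold lower number from compound 2 to compound 3 (0.68 log units; beyond the scatter) in this assay and so shows that this ring carbon is not indifferent to substitution. Within the data shown here, until now, the only measured step concerned the acyl group, so this is the first reading at this position, and a single added carbon is enough to move the number beyond the scatter. Going by these compounds, whether an ethyl group, a methoxy group or an amine at this carbon would act as methyl does remains open. No measurement shown bears on the cause of this step.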